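The compounds below may be only part of what the source reports. "The series", "measured", "known", "first", "only" and "open" are said of these compounds alone.

The shared core is that of compound 1 `O=C1NCCN1c1ccc(S(=O)(=O)Nc2ccc(C3CCCCC3)cc2)cc1`, which carries a cyclohexyl group on the aromatic carbon para to the sulfonamide-bearing ring. In a functional assay on HT-29 cells (Homo sapiens) for antiproliferative activity, read by sulforhodamine B assay, with a stated time of 48 h (on this read-out lower numbers stand for stronger inhibition and higher numbers for weaker inhibition), compound 1 gives only a limit, > 1000 nM, and that limit is the weakest result among the three measured compounds, as the limit of > 1000 nM in this assay, at which 1 of the 3 values shown sits, shows. Compound 3 `O=C1NCCN1c1ccc(S(=O)(=O)Nc2ccc(F)cc2)cc1` replaces that cyclohexyl by fluoro and gives 370 nM in this assay, so the step of an at least 2.7-fold lower number from compound 1 to compound 3 (0.43 log units; beyond the scatter) marks a real gain. Compound 2 `Cc1cccc(NS(=O)(=O)c2ccc(N3CCNC3=O)cc2)c1`, with 3-methylphenyl on the sulfonamide nitrogen, gives 110 nM, and the step of a 3.4-fold higher number from compound 2 to compound 3 (0.53 log units; beyond the scatter) shows how much the aryl partner matters on its own.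

Compound 4 `O=C1NCCN1c1ccc(S(=O)(=O)Nc2ccc(Br)cc2)cc1` differs from compound 1 by bromo in place of cyclohexyl on an aromatic carbon. Among the measured compounds shown here, the one step that bears directly on this change is an at least 2.7-fold lower number from compound 1 to compound 3 (0.43 log units; beyond the scatter), where a halogen in place of cyclohexyl moved the number down beyond the scatter; bromo is also a halogen, though larger than fluoro, so a similar direction is expected. The step from compound 1 to compound 4 is therefore estimated as an at least 2.0-fold lower number from compound 1 to compound 4 (0.30 log units; that floor lies within the scatter) in this assay. Compound 4 is accordingly expected to give about 500 nM, within a range from 150 nM to 1500 nM.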

Compound 4, half-maximal inhibitory concentration: 300 nM
For compound 4 the middle estimate is 1.7-fold (0.22 log units) above the measured one; measured number inside the range.
By their numbers in this assay, from the lowest: compound 2; then compounds 4 and 3 (each within the scatter of the next). At a limit, above all of these: compound 1.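

In this assay, bromo in place of cyclohexyl gives an at least 3.3-fold lower number from compound 1 to compound 4 (0.52 log units; beyond the scatter), so a second halogen on this aromatic carbon, para to a large group, moves the number in the same direction as fluoro did, while the exchange of one halogen for the other gives a 1.2-fold lower number from compound 3 to compound 4 (0.09 log units; within the scatter), and this assay does not separate the two. With bromo as with fluoro, the 4-halophenyl partner does not match 3-methylphenyl on the sulfonamide nitrogen, the change to 4-bromophenyl giving a 2.7-fold higher number from compound 2 to compound 4 (0.44 log units; beyond the scatter). Compound 1 remains a limit, so the steps away from it have only a floor and no true size: the limit of > 1000 nM in this assay, at which 1 of the 4 values shown sits.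

The compounds shown leave open whether the halogen itself matters or only the loss of cyclohexyl, a question that a hydrogen, a methyl or a methoxy at this place could settle, while an amine or a carboxylic acid would show how far the position tolerates a quite different group. It also remains open how a 3-bromophenyl or 3-fluorophenyl partner on the sulfonamide nitrogen would compare with 3-methylphenyl, as the steps shown change both the group and its place on the ring.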